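Swapping diethylamino for piperidin-1-yl on a shared core

The compounds below may be only part of what the source reports. "The series", "measured", "known", "first", "only" and "open" are said of these compounds alone.

- Compound 1 `CCN(CC)c1nc(Cl)nc2c1ncn2CCNc1ccnc2cc(Cl)ccc12`: > 11000 nM
- Compound 2 `Clc1ccc2c(NCCn3cnc4c(N5CCCC5)nc(Cl)nc43)ccnc2c1`: > 11100 nM

In an ADME assay on Vero cells (Chlorocebus sabaeus) for cytotoxicity, read by neutral red uptake, with a stated time of 48 h (a higher number here means a weaker inhibitor, a lower number a stronger inhibitor), compound 1 gives > 11000 nM, which is a limit and not a number. Compound 2 gives > 11100 nM, which is also a limit. Compound 3 `Clc1ccc2c(NCCn3cnc4c(N5CCCCC5)nc(Cl)nc43)ccnc2c1` keeps the core of compound 1 but carries piperidin-1-yl in place of diethylamino on an aromatic carbon. Among the measured compounds shown here, the one measured step that bears on this is a step that the two limits leave unreadable from compound 1 to compound 2, which puts pyrrolidin-1-yl in place of diethylamino. Given that step, no change beyond the scatter is expected, though it gives only weak guidance. The expected step is a number no higher from compound 1 to compound 3 (the limit leaves the size open). For compound 3 the estimated value is 11000 nM, with an expected range of 5000 nM to 15000 nM.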

Compound 3, half-maximal inhibitory concentration: > 10700 nM
Compound 3: a limit, no number; the forecaster's own chance of this, stated with the estimate: 75%; the middle value lies beyond the limit too.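

Among the compounds shown here, compound 1, compound 2 and compound 3 each give only a limit in this assay, and no step between them can be read. The compounds shown leave open whether swapping these amine groups changes the true value at all.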